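The compounds below may be only part of what the source reports. "The series", "measured", "known", "first", "only" and "open" are said of these compounds alone.

Measured so far in a functional assay on CNE-2 cells (Homo sapiens) for antiproliferative activity, read by sulforhodamine B assay, with a stated time of 48 h; on this read-out higher numbers stand for weaker inhibition and lower numbers for stronger inhibition:
- compound 1 `COc1cc(OC)c(C=C(C(=O)/C=C/c2cccc(OC)c2OC)C(=O)/C=C/c2cccc(OC)c2OC)c(OC)c1` (630 nM)
- compound 2 `COc1cccc(C=C(C(=O)/C=C/c2cccc(OC)c2OC)C(=O)/C=C/c2cccc(OC)c2OC)c1OC` (400 nM)

Going by the values given here, the one measured step is a 1.6-fold lower number from compound 1 to compound 2 (0.20 log units; within the scatter) and so compound 2 stands level with compound 1. Compound 3 `COc1cccc(/C=C/C(=O)C(=Cc2ccc(O)c(F)c2)C(=O)/C=C/c2cccc(OC)c2OC)c1OC` differs from compound 2 at one place: 3-fluoro-4-hydroxyphenyl in place of 2,3-dimethoxyphenyl on a double-bonded chain carbon bound to a double-bonded chain carbon. Among the compounds with values here, the only guide is that same-place step a 1.6-fold lower number from compound 1 to compound 2 (0.20 log units; within the scatter) and no measured compound carries the entering group, which leaves the expectation uncertain. In this assay the expected outcome is a 1.1-fold lower number from compound 2 to compound 3 (0.06 log units; within the scatter) and thus no step beyond the scatter. The estimate for compound 3 is 350 nM (expected range 90 nM to 1300 nM).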

Compound 3, half-maximal inhibitory concentration: 260 nM
Compound 3: the middle estimate sits 1.3-fold (0.13 log units) above what was measured; low and high end bracket the measured number.
By their numbers in this assay, from the lowest: compounds 3, 2 and 1 (each within the scatter of the next, the first and the last beyond it).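

In this assay the position on the double-bonded chain carbon accepts a quite different ring: 3-fluoro-4-hydroxyphenyl in place of 2,3-dimethoxyphenyl gives a 1.5-fold lower number from compound 2 to compound 3 (0.19 log units; within the scatter) and so no clear change, even though the entering ring brings a hydrogen-bond donor. Going by these compounds alone, in place of 2,4,6-trimethoxyphenyl the same ring gives a 2.4-fold lower number from compound 1 to compound 3 (0.38 log units; beyond the scatter) and this is the first step here beyond the scatter, though a modest one. No measurement shown explains either step. From the compounds shown here alone, the hydroxyl and the fluorine enter together, so their separate shares stay open. Going by these compounds, how an amine or a carboxylic acid on this ring would behave also stays open.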